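Swapping a nitro for an amino on a sulfonamide-linked core

The source may hold more compounds than are shown below. What is called first, only, known or untested is meant among the compounds shown, and "the series" means these compounds.

Measured compounds:
- compound 1, `COc1ccc(/C=C/S(=O)(=O)Nc2c(F)c(F)c(F)c(F)c2F)cc1[N+](=O)[O-]`, 75000 nM
- compound 2, `COc1ccc(/C=C/S(=O)(=O)Nc2c(F)c(F)c(F)c(F)c2F)cc1N`, 35000 nM
- compound 3, `COc1ccc(NS(=O)(=O)/C=C/c2c(OC)cc(OCCCC(=O)O)cc2OC)cc1[N+](=O)[O-]`, 100000 nM

These three compounds were tested in a functional assay on K562 cells (Homo sapiens) for cytotoxicity, read by trypan blue exclusion, with a stated time of 96 h; on this read-out higher numbers stand for weaker inhibition and lower numbers for stronger inhibition. Compound 1 and compound 2 share a core and differ in one place: amino in place of nitro on an aromatic carbon. This change gave a 2.1-fold lower number from compound 1 to compound 2 (0.33 log units; beyond the scatter), a small but real gain in potency.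

Compound 3 carries a different core; the difference between the core of compound 3 and that of compound 1 is not broken down here. In this assay compound 3 gives 100000 nM. Against compound 1 this lies within the scatter, so the two cannot be ranked, while against compound 2 compound 3 gives the higher number by a margin beyond the scatter.

Compound 4, `COc1ccc(NS(=O)(=O)/C=C/c2c(OC)cc(OCCCC(=O)O)cc2OC)cc1N`, has not yet been measured. It stands to compound 3 as compound 2 stands to compound 1: amino in place of nitro on an aromatic carbon. The surroundings of the changed position read identically in both pairs, so this is the same change. Among the measured compounds shown here, its only precedent here is the single pair compound 1 to compound 2. Because of a 2.1-fold lower number from compound 1 to compound 2 (0.33 log units; beyond the scatter), the step from compound 3 to compound 4 is expected to be of a similar size. That expectation means a step of a 2.1-fold lower number from compound 3 to compound 4 (0.32 log units; beyond the scatter). Compound 4 is therefore estimated at 48000 nM in this assay, with a likely range from 24000 nM to 95000 nM.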

Compound 4, half-maximal inhibitory concentration: 10000 nM
Estimate against measurement, compound 4: 4.8-fold (0.68 log units) above; the whole stated range lies above it.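

Putting amino in place of nitro again gave a stronger result in this assay, with a 10-fold lower number from compound 3 to compound 4 (1.00 log units; beyond the scatter), so the direction of the change carried over from the first core to the second. The size did not carry over, and the gap between the two steps is larger than ordinary scatter would produce: the same change on two cores in this assay, a 2.1-fold lower number (0.33 log units; beyond the scatter) from compound 1 to compound 2 and a 10-fold lower number (1.00 log units; beyond the scatter) from compound 3 to compound 4, 4.7-fold (0.67 log units) apart, beyond the scatter of two such steps

So on these two cores the change can be trusted for its direction but not for its size, and the step on one core is a poor guide to how large it will be on the other; the difference between the cores is not broken down here, and two pairs do not show which part of a core sets the size of the step or whether a third core would follow either one.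

The compounds shown leave open how other groups on the same aromatic carbon would compare, such as a hydroxyl, a methylamino or an acetamide in place of the amino. An ester in place of the carboxylic acid on compound 4 would also bear on whether that acid has any part in the larger step.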